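This account rests on a few compounds, and the source may have more. Where it says the series, first, only, none or still open, it means among the compounds named here.

Working notes on the series. The three measured compounds share one core and differ in a single group. Compound 1 `CC1CCN(C(=S)SCc2ccc(C(=O)Nc3ccccc3N)cc2)CC1` gives 81.9% in a functional assay on MGC-803 cells (Homo sapiens) for antiproliferative activity, read by CCK-8 assay, with a stated time of 72 h, tested at 8 uM; on this read-out higher numbers stand for a stronger effect at the one concentration tested and lower numbers for a weaker effect. Compound 2 `Nc1ccccc1NC(=O)c1ccc(CSC(=S)N2CCN(Cc3ccncc3)CC2)cc1` gives 79.3% in this assay. Compound 3 `COC(=O)c1ccc2c(c1)CCN2C(=S)SCc1ccc(C(=O)Nc2ccccc2N)cc1` gives 73.1% in this assay. On these three numbers compound 2 stands second highest; its nearest neighbour is compound 1, whose number lies within the scatter of it, and its furthest is compound 3, whose number also lies within the scatter, so none of the three can be set apart from the others on this read-out.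

Compound 4 `Cc1ccc(N2CCN(C(=S)SCc3ccc(C(=O)Nc4ccccc4N)cc3)CC2)cc1` is not yet measured. Its difference from compound 2 is 4-methylphenyl in place of (pyridin-4-yl)methyl on an amine nitrogen in a ring. For the measured compounds named here, no pair of measured compounds shows this change, so no measured step guides the size. The three measured numbers all lie within the scatter of one another despite differing groups at that point, which gives no ground to expect a step beyond the scatter from compound 2 to compound 4 in this assay in either direction. The expected step of a number 2.3 percentage points lower from compound 2 to compound 4 (within the scatter) is therefore small. Compound 4 is estimated at 77%, with a range from 62% to 88%.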

Compound 4, a percentage reported as inhibition, at one concentration (the size of the read-out at that concentration, not a potency): 19.8%
Estimate against measurement, compound 4: 57.2 percentage points above; measured number below the stated range.
By their numbers in this assay, from the lowest: compound 4; then compounds 3, 2 and 1 (each within the scatter of the next).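

In this assay, for the compounds shown here, the substituent on the amine nitrogen of the six-membered ring with 2 nitrogen proves able to carry a large effect: a number 59.5 percentage points lower from compound 2 to compound 4 (beyond the scatter), whereas the earlier compounds, all within the scatter of one another, gave no sign of a step of this size. The exchange keeps the heavy-atom count and a six-membered aromatic ring, yet it changes two things at once: the ring hetero atom and its hydrogen-bond acceptor are gone, and the aromatic ring now sits directly on the nitrogen rather than being linked through a methyl carbon. No measurement at hand bears on why the number falls at this position.

Which of these two differences carries the step stays open: a benzyl group and a pyridin-4-yl group on the same nitrogen would separate them. Also open, going by these compounds, is how a hydroxyl or a carboxylic acid on the phenyl ring of compound 4 would read in this assay.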